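This account rests on a few compounds, and the source may have more. Where it says the series, first, only, none or still open, it means among the compounds named here.

Compound 2 `Oc1ccc(O)c(-c2cc(-c3ccc(Cl)cc3)nn2-c2ccccc2)c1` stands lowest of the three measured compounds in a functional assay on cells (Cancer cell lines, Homo sapiens) for cytotoxicity, read by sulforhodamine B assay, with a stated time of 48 h (a higher number here means a weaker inhibitor of growth, a lower number a stronger inhibitor of growth), where compound 2 gives 6850 nM. Compound 1 `Oc1ccc(O)c(-c2cc(-c3ccccc3)nn2-c2ccccc2)c1` gives 26900 nM in this assay, and the step of a 3.9-fold lower number from compound 1 to compound 2 (0.59 log units; beyond the scatter) is the only one beyond the scatter. Compound 3 `NS(=O)(=O)c1ccc(-n2nc(-c3ccc(Cl)cc3)cc2-c2cc(O)ccc2O)cc1` gives 13000 nM in this assay; the step of a 1.9-fold higher number from compound 2 to compound 3 (0.28 log units; within the scatter) stays within the scatter.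

Compound 4 `O=C1C=CC(=O)C(c2cc(-c3ccc(Cl)cc3)nn2-c2ccccc2)=C1` differs from compound 2 by a group of 8 heavy atoms (6 carbon, 2 oxygen; one six-membered non-aromatic ring of carbon only) in place of a group of 8 heavy atoms (6 carbon, 2 oxygen; one six-membered aromatic ring of carbon only), on an aromatic carbon. Neither measured step bears on this change: both concerned a substituent on a phenyl ring, while the 2,5-dihydroxyphenyl group was kept in all three measured compounds. Among the compounds with values here, there is thus no measured step from which the size or direction of this change in this assay can be read. The expectation for compound 4 is therefore centred close to compound 2, with a wide range, as a step of a 1.4-fold lower number from compound 2 to compound 4 (0.14 log units; within the scatter). Compound 4 is estimated at 5000 nM in this assay, within a range from 1000 nM to 25000 nM.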

Compound 4, concentration for 50% growth inhibition: 53500 nM
Compound 4: middle estimate off by 11-fold (1.03 log units), on the low side; measured number above the stated range.
By their numbers in this assay, from the lowest: compounds 2 and 3 (each within the scatter of the next); then compounds 1 and 4 (each within the scatter of the next).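

In this assay, the change at this position gives a 7.8-fold higher number from compound 2 to compound 4 (0.89 log units; beyond the scatter), so replacing the 2,5-dihydroxyphenyl group with the non-aromatic six-membered ring weakens growth inhibition. Within the data shown here, this is the first sign that the carbon next to the ring nitrogen of the five-membered aromatic ring is sensitive to what it carries, which the earlier compounds could not show because they all kept the 2,5-dihydroxyphenyl group there. The exchange leaves the count of heavy atoms and hydrogen-bond acceptors unchanged, yet it removes both hydrogen-bond donors and the aromatic ring together, so these two differences cannot be separated here.

From the compounds shown here alone, whether a 2,5-dimethoxyphenyl group, which keeps the aromatic ring without the hydroxyl hydrogens, would stand nearer compound 2 or compound 4 remains open. Nothing shown gives a reason for the step.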